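Three Compounds at a Cytotoxicity Limit, and a Fourth

A few compounds are considered here, and "the series" means these few. Any claim that something is new, unique, unknown or untested is made for them only; others in the source may bear on it.

Compound 1, `CC(C)N(Cc1cccc(OCCCCCC(=O)O)c1)C(=O)c1ccc(-c2ccco2)cc1`, gives in an ADME assay on HEK293 cells (Homo sapiens) for cytotoxicity, read by CellTiter-Glo and resazurin assay, with a stated time of 72 h (a lower number here means that less compound is needed, a higher number that more compound is needed for the effect), a limit of > 26000 nM.
Compound 2, `CC(C)N(Cc1cccc(OCCCCCC(=O)O)c1)C(=O)c1ccc(-c2cccc(C(F)(F)F)c2)cc1`, gives in this assay a limit of > 26000 nM.
Compound 3, `CCOC(=O)CCCCCOc1cccc(CN(C(=O)c2ccc(-c3ccco3)cc2)C(C)C)c1`, gives in this assay a limit of > 26000 nM.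

Every value recorded in this assay is a limit rather than a number, and compound 3 therefore stands where the other two stand, at the same limit (the limit of > 26000 nM in this assay, at which 3 of the 3 values shown sit). Within the data shown here, the two steps measured within this group, a step that the two limits leave unreadable from compound 1 to compound 2 and a step that the two limits leave unreadable from compound 1 to compound 3, are unreadable in size for that reason; they show only that neither change moved a compound off the limit.

Compound 4, `CCOC(=O)CCCCCOc1cccc(CN(C(=O)c2ccc(-c3cc(OC)ccc3F)cc2)C(C)C)c1`, differs from compound 3 in one place: 2-fluoro-5-methoxyphenyl in place of furan-2-yl on an aromatic carbon. Among the measured compounds shown here, no measured step bears on this change in a readable way, so no direction of movement in this assay can be inferred from the data.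

Given that compound 3 sits at the limit, compound 4 is expected to sit there as well, with an estimated step that the limit leaves unreadable from compound 3 to compound 4. Compound 4 is estimated at 40000 nM, within a range of 20000 nM to 120000 nM, most likely reported again only as a limit.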

Compound 4, half-maximal effective concentration: > 26000 nM
Compound 4: a limit, no number (the forecaster's own chance of this, stated with the estimate: 85%); the middle value is on the limit's open side.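

Compound 3 and compound 4 both give only a limit in this assay, so no step between them can be read: the limit of > 26000 nM in this assay, at which 4 of the 4 values shown sit.

The compounds shown leave open at what concentration any of them would reach the effect, and whether furan-2-yl and 2-fluoro-5-methoxyphenyl differ at all in this assay.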